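Isoxazole series: amide to benzyl swap at the aryl nitrogen

The source may hold more compounds than are shown below. What is called first, only, known or untested is meant among the compounds shown, and "the series" means these compounds.

Two compounds of this series have numbers in an assay on isolated protein for agonist activity at Bile acid receptor (Homo sapiens), read by FRET (on this read-out lower numbers stand for smaller maximal responses and higher numbers for larger maximal responses), so far. Compound 1 `CC(C)c1onc(-c2c(Cl)cccc2Cl)c1COc1ccc(N(C)C(=O)c2cccc(C(=O)O)c2)c(C(F)(F)F)n1` gives 110% and stands highest of the two, with compound 2 `Cc1cc(OCc2c(-c3c(Cl)cccc3Cl)noc2C(C)C)ncc1[N+](=O)[O-]` as its nearest neighbour; in this assay compound 2 gives 101%, a number within the scatter of compound 1, so the two are not distinguished. Going by the values given here, no step between measured compounds that differ in one place is available, so nothing in the measured set yet shows how a single change moves the maximal response.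

Compound 3 `CC(C)c1onc(-c2c(Cl)cccc2Cl)c1COc1ccc(N(C)Cc2cccc(C(=O)O)c2)c(C(F)(F)F)n1` is not yet measured. It differs from compound 1 in one place (3-carboxybenzyl in place of (3-carboxyphenyl)carbonyl on a nitrogen on an aromatic ring); the amide carbonyl of compound 1 is gone and the carboxyphenyl group is joined through a saturated carbon instead.

Among the compounds with values here, with no measured step of this kind to lean on, the expectation for compound 3 rests on the value of compound 1, which is 110%. The step from compound 1 to compound 3 in this assay is expected to be small and downward, at most just beyond the scatter: a number 15 percentage points lower from compound 1 to compound 3 (beyond the scatter). Compound 3 is therefore estimated at 95%, with a range from 55% to 120%.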

Compound 3, largest response reached (reported as efficacy), in percent of the reference or control that the assay uses: 102%
Compound 3: middle estimate off by 7 percentage points, on the low side; the measured number falls inside the stated range.
By their numbers in this assay, from the lowest: compounds 2, 3 and 1 (each within the scatter of the next).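

In this assay, going by these compounds alone, the first single-place step reads a number 8 percentage points lower from compound 1 to compound 3 (within the scatter), with 3-carboxybenzyl in place of (3-carboxyphenyl)carbonyl on a nitrogen on an aromatic ring. The swap removes the amide carbonyl and joins the carboxyphenyl group through a saturated carbon, yet the maximal responses of this pair are not distinguished, so for these two structures the response in this assay does not depend on that carbonyl being present. Nothing measured here offers an explanation for this outcome.

Within the data shown here, the single step does not show whether the same holds for other groups on this nitrogen, such as a 2-(3-carboxyphenyl)ethyl group with its longer chain, or for a tetrazole or primary amide in place of the carboxylic acid on the benzyl ring. It also leaves open what an ethyl group or a hydrogen would do in place of the methyl on that nitrogen, and, as the read-out is maximal response alone, how the swap bears on the concentration needed to reach that response.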